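Indole nitrogen methylation in the trimethoxyphenyl series

The source may report more compounds than this note shows. Statements on the series, on what has been measured and on what is new or still open speak of the compounds shown alone.

Measured so far in a functional assay on HCT-116 cells (Homo sapiens) for inhibition, read by CCK-8 assay, with a stated time of 48 h; a higher number here means a weaker inhibitor, a lower number a stronger inhibitor:
- compound 1 (`COc1cc(-c2ccnc3cc(-c4ccccc4)nn23)cc(OC)c1OC`), 3880 nM
- compound 2 (`COc1cc(-c2ccnc3cc(-c4ccc5cc[nH]c5c4)nn23)cc(OC)c1OC`), 187 nM

Compound 2 holds the lower of the two numbers, set apart by a large step (a 21-fold lower number from compound 1 to compound 2 (1.32 log units; beyond the scatter)) with 1H-indol-6-yl in place of phenyl on an aromatic carbon. Compound 3 (`COc1cc(-c2ccnc3cc(-c4ccc5ccn(C)c5c4)nn23)cc(OC)c1OC`) differs from compound 2 by methyl in place of hydrogen on an aromatic nitrogen. For the measured compounds named here, the one measured step bears only indirectly, since no measured pair varies this nitrogen. On these data alone, a step of comparable size is therefore not expected in this assay, and the direction remains open. The expected step (a 1.2-fold lower number from compound 2 to compound 3 (0.10 log units; within the scatter)) stays small. For compound 3 the estimate is 150 nM (expected range 40 nM to 600 nM).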

Compound 3, half-maximal inhibitory concentration: 1040 nM
Compound 3: middle estimate off by 6.9-fold (0.84 log units), on the low side; the whole stated range lies below it.
By their numbers in this assay, from the lowest: compound 2; then compound 3; then compound 1.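

Methyl in place of hydrogen on this aromatic nitrogen is not a neutral change: the series shows a 5.6-fold higher number from compound 2 to compound 3 (0.75 log units; beyond the scatter) and places the methylated indole well short of compound 2. The indole still keeps part of its gain over phenyl, with a 3.7-fold lower number from compound 1 to compound 3 (0.57 log units; beyond the scatter) on the same core. Nothing measured here accounts for the loss on methylation.

Open, on these data alone, is whether an ethyl group, or a longer chain ending in an amine, on this nitrogen would raise the number further or bring it back towards that of compound 2.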